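A few compounds are considered here, and "the series" means these few. Any claim that something is new, unique, unknown or untested is made for them only; others in the source may bear on it.

Measured so far:
compound 1 `O=[N+]([O-])c1ccccc1OC(CCn1ccnc1)c1ccccc1` — 18 ug/mL
compound 2 `O=[N+]([O-])c1ccc(OC(CCn2ccnc2)c2ccccc2)c(F)c1` — 25.1 ug/mL
compound 3 `CC(CCn1ccnc1)Oc1ccc([N+](=O)[O-])cc1F` — 15 ug/mL

All three were tested in an ADME assay on J774.A1 cells (Mus musculus) for cytotoxicity, read by MTT assay; a higher number here means that more compound is tolerated, a lower number that less compound is tolerated. Compound 2 and compound 3 share a core and differ in one place, (methyl in place of phenyl on a saturated chain carbon bound to an oxygen on an aromatic ring and a saturated chain carbon); this change gave a 1.7-fold lower number from compound 2 to compound 3 (0.22 log units; within the scatter), so the two numbers cannot be told apart with confidence. Compound 1 has a different core from compound 2, and how the two cores differ is not broken down here; what can be said is that the values of compound 1 and compound 2 lie within the scatter of each other, as do those of compound 1 and compound 3.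

Compound 4 `CC(CCn1ccnc1)Oc1ccccc1[N+](=O)[O-]` has not yet been measured. It stands to compound 1 as compound 3 stands to compound 2: the change is methyl in place of phenyl on a saturated chain carbon bound to an oxygen on an aromatic ring and a saturated chain carbon, and the place is the same in both pairs, so this is the same change. Because the earlier step was a 1.7-fold lower number from compound 2 to compound 3 (0.22 log units; within the scatter), the step from compound 1 to compound 4 is expected to be of similar size, a 1.5-fold lower number from compound 1 to compound 4 (0.18 log units; within the scatter). For compound 4 the estimate in this assay is 12 ug/mL, between 6 ug/mL and 24 ug/mL.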

Compound 4, half-maximal cytotoxic concentration: > 100 ug/mL
Compound 4 ended at the assay's limit; the forecaster's own chance of this, stated with the estimate: 5%; middle value at least 8.3-fold (0.92 log units) from the limit.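

Methyl in place of phenyl on the saturated chain carbon gave an at least 5.5-fold higher number from compound 1 to compound 4 (0.74 log units; beyond the scatter) in this assay. Compound 4 reads > 100 ug/mL, which is a limit of the assay and not a number. The same change therefore cannot be carried from one core to the other at a fixed size, although these two pairs do not show what in the cores sets the outcomes apart, or how the change would behave on any third core: the same change on two cores in this assay, a 1.7-fold lower number (0.22 log units; within the scatter) from compound 2 to compound 3 and an at least 5.5-fold higher number (0.74 log units; beyond the scatter) from compound 1 to compound 4, at least 9.2-fold (0.96 log units) apart, beyond the scatter of two such steps

The compounds shown leave open whether an ethyl group or a longer chain at this place would give a number closer to that of the phenyl compounds or to that of the methyl compounds. They also leave open how an amine or a carboxylic acid at the same place would read in this assay on either core.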